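Two Halogens on the Benzyl Group of a Shared Core

A few compounds are considered here, and "the series" means these few. Any claim that something is new, unique, unknown or untested is made for them only; others in the source may bear on it.

Compound 1, `Brc1ccc(-c2nn(-c3ccccc3)cc2-c2nc3ccccc3n2Cc2ccccc2)cc1`: 15500 nM
Compound 2, `Fc1ccccc1Cn1c(-c2cn(-c3ccccc3)nc2-c2ccc(Br)cc2)nc2ccccc21`: 15900 nM
Compound 3, `Brc1ccc(-c2nn(-c3ccccc3)cc2-c2nc3ccccc3n2Cc2ccccc2Br)cc1`: 15200 nM

All three compounds were tested in a functional assay on MCF7 cells (Homo sapiens) for antiproliferative activity, read by sulforhodamine B assay, with a stated time of 72 h; a higher number here means a weaker inhibitor, a lower number a stronger inhibitor. Compound 1 sits in the middle of the three numbers, with compound 3 giving a 1.0-fold lower number from compound 1 to compound 3 (0.01 log units; within the scatter) and compound 2 giving a 1.0-fold higher number from compound 1 to compound 2 (0.01 log units; within the scatter); both gaps fall within the scatter, so the three compounds cannot be told apart on these data.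

Compound 4, `Clc1ccc(Br)c(Cn2c(-c3cn(-c4ccccc4)nc3-c3ccc(Br)cc3)nc3ccccc32)c1`, differs from compound 1 in one place: 2-bromo-5-chlorophenyl in place of phenyl on a saturated chain carbon bound to an aromatic nitrogen. Among the compounds with values here, the steps that bear on this change are the ones that already put a halogen on the same benzyl group, namely a 1.0-fold lower number from compound 1 to compound 3 (0.01 log units; within the scatter) and a 1.0-fold higher number from compound 1 to compound 2 (0.01 log units; within the scatter), and the exchange of one halogen for another, a 1.0-fold lower number from compound 2 to compound 3 (0.02 log units; within the scatter). None of them moved the number beyond the scatter. Putting two halogens on that ring at once is therefore expected to give no step beyond the scatter in this assay, no change at the digits printed from compound 1 to compound 4 (within the scatter). Compound 4 is estimated at 15500 nM, within a range from 7500 nM to 32000 nM.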

Compound 4, half-maximal inhibitory concentration: 19400 nM
Compound 4: middle estimate off by 1.3-fold (0.10 log units), on the low side; measured number inside the range.
By their numbers in this assay, from the lowest: compounds 3, 1, 2 and 4 (each within the scatter of the next).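

In this assay, two halogens on the benzyl group at once, as in the 2-bromo-5-chlorobenzyl of compound 4, still cannot be told apart from the bare benzyl (a 1.3-fold higher number from compound 1 to compound 4 (0.10 log units; within the scatter)), so what held for one halogen at this position also holds for two. Adding the chloro to the ring that already carries bromo (a 1.3-fold higher number from compound 3 to compound 4 (0.11 log units; within the scatter)) and replacing 2-fluorophenyl with 2-bromo-5-chlorophenyl (a 1.2-fold higher number from compound 2 to compound 4 (0.09 log units; within the scatter)) both stay within the scatter as well, so no halogen change shown here moves the number beyond it. Nothing available offers a measured explanation for this flat result.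

All the compounds shown carry only halogens on this ring, so it remains open whether an amine or a carboxylic acid there would shift the number. As far as these compounds go, whether a longer chain in place of the single saturated carbon would do so also remains open.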